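From Phenylethenyl to Chlorophenyl at the Ring Amine

The source may hold more compounds than are shown below. What is called first, only, known or untested is meant among the compounds shown, and "the series" means these compounds.

Compound 3 `COc1cc(N)c(Cl)cc1NC(=O)C1CCN(C/C=C/c2ccccc2)CC1` gives > 10 mg/kg in a functional assay on the whole organism for antagonist activity, with Mus musculus as the target (a lower number here means that less compound is needed, a higher number that more compound is needed for the effect), which is a limit and not a number. Compound 1 `CCCCCCN1CCC(C(=O)Nc2cc(Cl)c(N)cc2OC)CC1` likewise returns only a limit there, > 10 mg/kg. Compound 2 `COc1cc(N)c(Cl)cc1NC(=O)C1CCN(Cc2cccc(C)c2)CC1` instead gives 2.4 mg/kg. Two of the three values sit at the limit of > 10 mg/kg in this assay, at which 2 of the 3 values shown sit. The step of an at least 4.1-fold lower number from compound 1 to compound 2 (0.61 log units; beyond the scatter) is at least modest, the step of an at least 4.1-fold higher number from compound 2 to compound 3 (0.61 log units; beyond the scatter) is at least modest in the opposite direction, and the step that the two limits leave unreadable from compound 1 to compound 3 cannot be read. Compound 4 `COc1cc(N)c(Cl)cc1NC(=O)C1CCN(Cc2ccccc2Cl)CC1` arises through (2-chlorophenyl in place of 2-phenylethenyl on a saturated chain carbon bound to an amine nitrogen in a ring). Guided by compound 2, which gave 2.4 mg/kg with a 2-chlorobenzyl-like benzyl arrangement, the expected step is an at least 3.3-fold lower number from compound 3 to compound 4 (0.52 log units; beyond the scatter), a lower number. Compound 4 is therefore estimated at 3 mg/kg, within 1 mg/kg to 10 mg/kg.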

Compound 4, dose for half-maximal effect: > 4 mg/kg
Compound 4 ended at the assay's limit; the forecaster's own chance of this, stated with the estimate: 30%; middle value at least 1.3-fold (0.12 log units) away from the limit.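

In this assay compound 4 gives > 4 mg/kg, which is a limit and not a number, so 2-chlorophenyl at this place adds a second aromatic group without a measured dose. Set against 3-methylphenyl, the change reads an at least 1.6-fold higher number from compound 2 to compound 4 (0.22 log units; that floor lies within the scatter), and that floor alone does not separate the two groups. The steps to compound 4 from compound 1 and compound 3 cannot be read. On these data alone, whether 2-chlorophenyl truly needs a higher dose than 3-methylphenyl stays open. So does what a plain phenyl or a 2-methylphenyl group would give at this place.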